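From compound 1 to compound 4: a new nitrogen substituent

This account rests on a few compounds, and the source may have more. Where it says the series, first, only, none or still open, it means among the compounds named here.

compound 1 `COc1cc(/C=C2\CNC/C(=C\c3cc(OC)c(OC)c(OC)c3)C2=O)cc(OC)c1OC` gives 1500 nM
compound 2 `CCCN1C/C(=C\c2ccc(OC)c(OC)c2)C(=O)/C(=C/c2ccc(OC)c(OC)c2)C1` gives 4100 nM
compound 3 `CCN1C/C(=C\c2ccc(OC)c(OC)c2)C(=O)/C(=C/c2ccc(OC)c(OC)c2)C1` gives 3600 nM

Within the data shown here, all three values come from a functional assay on NCI-H460 cells (Homo sapiens) for cytotoxicity, read by MTT assay, with a stated time of 72 h (on this read-out lower numbers stand for stronger inhibition and higher numbers for weaker inhibition), and are the only measurements so far. Compound 1 has the lowest number of the three, and its gaps to compound 2 and to compound 3 both lie beyond the scatter. Compound 1 differs from these two in more than one place, so those gaps cannot be assigned to any single change.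

Compound 4 `COc1cc(/C=C2\CN(C(=O)c3ccccc3F)C/C(=C\c3cc(OC)c(OC)c(OC)c3)C2=O)cc(OC)c1OC` keeps the core of compound 1 and differs from it by one change: (2-fluorophenyl)carbonyl in place of hydrogen on an amine nitrogen in a ring.

Among the measured compounds shown here, only one measured step touches a substituent on that nitrogen. That step, a 1.1-fold lower number from compound 2 to compound 3 (0.06 log units; within the scatter), lies within the scatter, but it concerns only a saturated chain. For the measured compounds named here, no measured compound carries a carbonyl group on the nitrogen, and the data show no direction for such a change. With this thin guide, no step beyond the scatter is expected in this assay, and the range is kept wide. The expected step is a 1.7-fold lower number from compound 1 to compound 4 (0.22 log units; within the scatter). For compound 4 the estimate is 900 nM, with an expected range from 200 nM to 4000 nM.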

Compound 4, half-maximal inhibitory concentration: 1500 nM
Compound 4: the middle estimate sits 1.7-fold (0.22 log units) below what was measured; low and high end bracket the measured number.
By their numbers in this assay, from the lowest: compounds 1 and 4 (each within the scatter of the next); then compounds 3 and 2 (each within the scatter of the next).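

In this assay, replacing hydrogen with (2-fluorophenyl)carbonyl on the amine nitrogen in the ring gives no change at the digits printed from compound 1 to compound 4 (within the scatter). Among these compounds, the only earlier step at this nitrogen involved saturated chains, so this is the first reading for a carbonyl-linked aromatic group there: on the core of compound 1, a substituent of 9 heavy atoms leaves the number where it was, and the hydrogen on this nitrogen is not needed for a number of this size. No measurement at hand bears on why the number holds with so large a group on this nitrogen.

This single step cannot separate the contributions of the carbonyl, the aromatic ring and the fluorine, so a plain phenylcarbonyl, a small acetyl group or a chain ending in an amine or a carboxylic acid on the same nitrogen would each test a different part of the question. An ethyl or propyl group on the core of compound 1 would also be needed to link the saturated chains of compound 2 and compound 3 to this series, since those two compounds differ from compound 1 in more than one place.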